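A Long Side Chain Added to a Weak Ether

This account rests on a few compounds, and the source may have more. Where it says the series, first, only, none or still open, it means among the compounds named here.

Compound 3, with structure `CN1CCC(COC(c2ccccc2)c2ccccc2)CC1`, gives only a limit of the assay, > 20000 nM, in a functional assay on cells (T-cell line, Homo sapiens) for inhibition; on this read-out lower numbers stand for stronger inhibition and higher numbers for weaker inhibition. Two related compounds carry a longer chain on the ring nitrogen: compound 1, `COc1ccc(CCCN2CCC(COCc3ccc(Cl)cc3)CC2)cc1`, gives 500 nM in this assay, and compound 2, `COc1ccc(CCCN2CCC(COCc3ccccn3)CC2)cc1`, gives 5900 nM. Among the compounds with values here, the one measured step, a 12-fold higher number from compound 1 to compound 2 (1.07 log units; beyond the scatter), concerns the ether end rather than the nitrogen, so it does not bear directly on the change considered here. Compound 4, `COc1ccc(/C=C/CN2CCC(COC(c3ccccc3)c3ccccc3)CC2)cc1`, differs from compound 3 by 2-(4-methoxyphenyl)ethenyl in place of hydrogen on a saturated chain carbon bound to an amine nitrogen in a ring. Within the data shown here, no measured pair covers exactly this change; what the data show is that compounds 1 and 2, both carrying a methoxyphenyl-bearing chain on the ring nitrogen, sit at numbers inside the measurable range, while compound 3, with only a hydrogen there, sits at the limit (the limit of > 20000 nM in this assay, at which 1 of the 3 values shown sits). Compound 4 is therefore expected to give about 2500 nM, within 400 nM to 15000 nM, a guess anchored on compound 1 at 500 nM and compound 2 at 5900 nM. This corresponds to an expected at least 8.0-fold lower number from compound 3 to compound 4 (0.90 log units; beyond the scatter).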

Compound 4, half-maximal inhibitory concentration: 4300 nM
For compound 4 the middle estimate is 1.7-fold (0.24 log units) below the measured one, within the range that was stated.
By their numbers in this assay, from the lowest: compound 1; then compounds 4 and 2 (each within the scatter of the next). At a limit, above all of these: compound 3.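

Within the data shown here, putting 2-(4-methoxyphenyl)ethenyl in place of hydrogen on a saturated chain carbon bound to an amine nitrogen in a ring gives the first direct comparison at this position: in this assay, the change produces an at least 4.6-fold lower number from compound 3 to compound 4 (0.66 log units; beyond the scatter). Among these compounds, the ether end stays the same in this step, so the change in number belongs to the added group alone, which the earlier compounds, with their different ether ends, could not show. Compound 3 sits only at a limit, so the step sets a minimum and not an exact size: the limit of > 20000 nM in this assay, at which 1 of the 4 values shown sits.

The compounds shown leave open which part of the added group matters, for example whether a plain phenyl group or a saturated chain in place of the double bond would serve as well. On these data alone, how an amine or a carboxylic acid in place of the methoxy group would read in this assay also remains open.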